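Methyl on the sulfonyl phenyl in a cyanothiophene hydrazide

The source may report more compounds than this note shows. Statements on the series, on what has been measured and on what is new or still open speak of the compounds shown alone.

The series is followed in a functional assay on HepG2 cells (Homo sapiens) for cytotoxicity, read by sulforhodamine B assay, with a stated time of 48 h; a lower number here means a stronger inhibitor, a higher number a weaker inhibitor. Two compounds carry measured numbers. Compound 1 `C/C(=N\NC(=O)CC#N)c1ccc(NS(=O)(=O)c2ccc(C)cc2)cc1` gives 26000 nM. Compound 2 `C/C(=N\NC(=O)c1sc(N)c(C#N)c1N)c1ccc(NS(=O)(=O)c2ccccc2)cc1` gives 23300 nM. Going by the values given here, compound 2 holds the lowest of the two numbers, but its nearest neighbour is compound 1, whose number lies within the scatter of repeated measurement, so the two values are read as indistinguishable, and no ordering of the pair is claimed. Among the compounds with values here, no step between compounds that differ in one place is available from these two structures, since compound 1 and compound 2 differ in more than one place at once.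

Compound 3 `C/C(=N\NC(=O)c1sc(N)c(C#N)c1N)c1ccc(NS(=O)(=O)c2ccc(C)cc2)cc1` is not yet measured. It differs from compound 2 in one place: methyl in place of hydrogen on an aromatic carbon. The change sits on an aromatic carbon of a six-membered aromatic ring of carbon only, para to a large group. The data hold no measured step of this kind in this assay, so the expected change is small. The step is estimated as a 1.1-fold lower number from compound 2 to compound 3 (0.02 log units; within the scatter), in no direction beyond the scatter. Compound 3 is therefore expected at 22000 nM, within a range from 9000 nM to 55000 nM.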

Compound 3, half-maximal inhibitory concentration: 21800 nM
The estimate for compound 3 lay 1.0-fold (0.00 log units) above the measured number; the measured number falls inside the stated range.
By their numbers in this assay, from the lowest: compounds 3, 2 and 1 (each within the scatter of the next).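

In this assay, methyl in place of hydrogen on an aromatic carbon, para to a large group, now has a single-place reading: a 1.1-fold lower number from compound 2 to compound 3 (0.03 log units; within the scatter) and so, at this position, phenylsulfonyl and (4-methylphenyl)sulfonyl cannot be told apart in this assay. Compound 3 also links the two earlier structures, which differed in more than one place, and 3,5-diamino-4-cyanothiophen-2-yl in place of cyanomethyl on a carbonyl carbon gives a 1.2-fold lower number from compound 1 to compound 3 (0.08 log units; within the scatter) and thus also stays within the scatter. No measurement at hand accounts for either result.

Whether a chlorine, a methoxy group, a carboxylic acid or a longer alkyl chain at the same aromatic carbon would move the number beyond the scatter remains open, since methyl is the only replacement for hydrogen shown there. Also open, from the compounds shown here alone, is whether an amine or a morpholine on the carbonyl carbon, in place of the 3,5-diamino-4-cyanothiophen-2-yl group, would separate from the values shown.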